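The source may hold more compounds than are shown below. What is called first, only, known or untested is meant among the compounds shown, and "the series" means these compounds.

Working notes on the series. Compound 1 `CN1CCN(CCC(=O)OC2CC3(N4CCCC4)CC(c4ccccc4)C2C(c2ccccc2)C3)CC1`, compound 2 `CN1CCN(CCC(=O)OC2CC3(N(C)C)CC(c4ccccc4)C2C(c2ccccc2)C3)CC1` and compound 3 `CN1CCN(CCN2CCC3(N(C)C)CC(c4ccccc4)C2C(c2ccccc2)C3)CC1` have been run in an ADME assay on L6 cells (Rattus norvegicus) for cytotoxicity; a lower number here means a stronger inhibitor, a higher number a weaker inhibitor. Compound 1 gives 21300 nM, compound 2 gives 31100 nM and compound 3 gives 70300 nM, the highest number of the three. The difference between the core of compound 3 and the core of compound 2 is not broken down here. Compound 2 and compound 1 differ by pyrrolidin-1-yl in place of dimethylamino on a saturated ring carbon, and that gave a 1.5-fold lower number from compound 2 to compound 1 (0.16 log units; within the scatter).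

Compound 4 `CN1CCN(CCN2CCC3(N4CCCC4)CC(c4ccccc4)C2C(c2ccccc2)C3)CC1` has not yet been measured in this assay. Among the compounds with values here, it differs from compound 3 by pyrrolidin-1-yl in place of dimethylamino on a saturated ring carbon, the same kind of change as the one from compound 2 to compound 1, though the surroundings are not identical: around the earlier change the place shows two ring bonds from the ring atom that bears a large group and two ring bonds from the ring atom that bears a phenyl group, whereas around the new one it shows two ring bonds from two ring atoms that each bear a phenyl group. Because the earlier instance gave a 1.5-fold lower number from compound 2 to compound 1 (0.16 log units; within the scatter), the step from compound 3 to compound 4 is expected to be a 1.3-fold lower number from compound 3 to compound 4 (0.11 log units; within the scatter), again within the scatter. Compound 4 is estimated at 55000 nM, between 30000 nM and 110000 nM.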

Compound 4, half-maximal inhibitory concentration: 50300 nM
Compound 4: middle estimate off by 1.1-fold (0.04 log units), on the high side; the measured number falls inside the stated range.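

In this assay, pyrrolidin-1-yl in place of dimethylamino on a saturated ring carbon gives a 1.4-fold lower number from compound 3 to compound 4 (0.15 log units; within the scatter), and the step on the core of compound 3 matches the one on the core of compound 2: the same change on two cores in this assay, a 1.5-fold lower number (0.16 log units; within the scatter) from compound 2 to compound 1 and a 1.4-fold lower number (0.15 log units; within the scatter) from compound 3 to compound 4, 1.0-fold (0.02 log units) apart, within the scatter of two such steps. Within the data shown here, both steps lie within the scatter, so the agreement shows only that this change leaves the number practically unmoved on these two cores, not that pyrrolidin-1-yl gives a real shift common to both. Two cores are a narrow base, and they say nothing on whether the same holds on a further core or for a change that reaches beyond these two amines.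

The compounds shown carry only dimethylamino and pyrrolidin-1-yl at this place, so it stays open how a six-membered ring amine such as piperidin-1-yl or morpholin-4-yl, or a primary amine, would read here. Also open is how a larger step at this place would carry from one core to the other, since neither step shown rises above the scatter.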